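From ethyl(methyl)amino to diethylamino: one more methyl

The source may report more compounds than this note shows. Statements on the series, on what has been measured and on what is new or still open speak of the compounds shown alone.

Measured so far in a functional assay (Trachealis) with Cavia porcellus as the target; on this read-out higher numbers stand for an effect only at larger amounts of compound and lower numbers for an effect already at smaller amounts:
- compound 1 `C/N=C(/NC#N)C1=CC(C)(C)Oc2ccc(C#N)cc21` gives 646 nM
- compound 2 `CN(C)/C(=N\C#N)C1=CC(C)(C)Oc2ccc([N+](=O)[O-])cc21` gives 51.3 nM
- compound 3 `CCN(C)/C(=N\C#N)C1=CC(C)(C)Oc2ccc([N+](=O)[O-])cc21` gives 178 nM

Compound 3 at 178 nM has the second highest of the three numbers, with compound 2 lower and compound 1 higher, both gaps beyond the scatter. Compound 4 `CCN(CC)/C(=N\C#N)C1=CC(C)(C)Oc2ccc([N+](=O)[O-])cc21` follows from compound 3 through methyl in place of hydrogen on a saturated chain carbon bound to an amine nitrogen in the form of methyl in place of hydrogen on a saturated chain carbon bound to an amine nitrogen. Among the measured compounds shown here, one measured step bears on this, the same change: a 3.5-fold higher number from compound 2 to compound 3 (0.54 log units; beyond the scatter) and it is modest but beyond the scatter. A step of similar size toward a higher number is therefore expected in this assay and one step is thin support. The expected step is a 2.9-fold higher number from compound 3 to compound 4 (0.47 log units; beyond the scatter) as estimated from that precedent. Expected for compound 4 is 520 nM (estimated range 190 nM to 1400 nM).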

Compound 4, half-maximal effective concentration: < 31700 nM
Compound 4: a limit, no number; the forecaster's own chance of this, stated with the estimate: 3%; the middle value does not contradict the limit.
By their numbers in this assay, from the lowest: compound 2; then compound 3; then compound 1.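

In this assay compound 4 gives < 31700 nM, a limit and not a number. The steps to it from compound 2 and compound 3 cannot be read. The compounds shown leave open whether diethylamino in compound 4 changes the number in the same direction as ethyl(methyl)amino in compound 3 did.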